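From 5-fluoropyridin-3-yl to 1,3-benzoxazol-5-yl: One Ring Swap

A few compounds are considered here, and "the series" means these few. Any claim that something is new, unique, unknown or untested is made for them only; others in the source may bear on it.

Of the compounds shown here, three with a shared core have been tested in an ADME assay (liver) for metabolic stability, with Liver microsome (Homo sapiens) as the target, using microsomes and NADPH, with a stated time of 30 min, tested at 1 uM (on this read-out higher numbers stand for fast clearance and lower numbers for slow clearance), so far. Compound 1 `Nc1ccc(S(=O)(=O)N2CCN(c3ncc(C(O)(C(F)(F)F)C(F)(F)F)cc3-c3ccoc3)CC2)cn1` gives only a limit of < 14 mL.min-1.g-1 and no exact number. Compound 2 `Cc1csc(-c2cc(C(O)(C(F)(F)F)C(F)(F)F)cnc2N2CCN(S(=O)(=O)c3ccc(N)nc3)CC2)c1` gives 29 mL.min-1.g-1 and compound 3 `Nc1ccc(S(=O)(=O)N2CCN(c3ncc(C(O)(C(F)(F)F)C(F)(F)F)cc3-c3cncc(F)c3)CC2)cn1` gives 24 mL.min-1.g-1 in this test. These two numbers cannot be told apart, as the step of a 1.2-fold lower number from compound 2 to compound 3 (0.08 log units; within the scatter) shows.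

Compound 4 `Nc1ccc(S(=O)(=O)N2CCN(c3ncc(C(O)(C(F)(F)F)C(F)(F)F)cc3-c3ccc4ocnc4c3)CC2)cn1` has 1,3-benzoxazol-5-yl in place of 5-fluoropyridin-3-yl on an aromatic carbon, ortho to a large group 1,3-benzoxazol-5-yl in place of 5-fluoropyridin-3-yl on an aromatic carbon in the same place as the earlier swaps. Two other swaps there start from the limit of compound 1, giving an at least 2.0-fold higher number from compound 1 to compound 2 (0.31 log units; beyond the scatter) and an at least 1.7-fold higher number from compound 1 to compound 3 (0.23 log units; that floor lies within the scatter) as the steps. Going by the values given here, the closest guide is compound 3, whose group swap from compound 2 gave only the step of a 1.2-fold lower number from compound 2 to compound 3 (0.08 log units; within the scatter) and so no clear shift. No step beyond the scatter is therefore expected in this assay here, and the estimated step is a 1.2-fold higher number from compound 3 to compound 4 (0.07 log units; within the scatter) for this swap. The estimate for compound 4 is 28 mL.min-1.g-1 with an expected range from 14 mL.min-1.g-1 to 58 mL.min-1.g-1 in this test.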

Compound 4, intrinsic clearance in microsomes: < 14 mL.min-1.g-1
Compound 4 ended at the assay's limit; the forecaster's own chance of this, stated with the estimate: 15%; middle value at least 2.0-fold (0.30 log units) away from the limit.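

Until now, only furan-3-yl had reached the limit of this assay at this position; 1,3-benzoxazol-5-yl reaches it too, so a group with more heavy atoms than 5-fluoropyridin-3-yl can sit here and still give a low number. Compared with 4-methylthiophen-2-yl, the new group gives an at least 2.0-fold lower number from compound 2 to compound 4 (0.31 log units; beyond the scatter), and compared with 5-fluoropyridin-3-yl, it gives an at least 1.7-fold lower number from compound 3 to compound 4 (0.23 log units; that floor lies within the scatter). The step from compound 1 to compound 4 cannot be read, because both compounds stand at the same limit: the limit of < 14 mL.min-1.g-1 in this assay, at which 2 of the 4 values shown sit.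

As far as these compounds go, the true numbers of compound 1 and compound 4 remain unknown, so furan-3-yl and 1,3-benzoxazol-5-yl cannot be ranked against each other. The compounds shown also leave open how an amine or a carboxylic acid at this position, in place of an aromatic ring, would read in this assay.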